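Notes on the step from compound 2 to compound 3

The source may hold more compounds than are shown below. What is called first, only, known or untested is meant among the compounds shown, and "the series" means these compounds.

Measured in an ADME assay on the whole organism (Mus musculus, strain CD-1) for pharmacokinetics, at a dose of 10 mg/kg by the oral route; a lower number here means less compound in the circulation, a higher number more compound in the circulation at the dose given:
- compound 1 `CCOc1cc([C@](O)(CCN(C)C)[C@@H](c2cc3cc(Br)ccc3nc2OC)c2ccnc(OC)c2OC)cc(OC)n1` gives 12700 ng.h/mL
- compound 2 `COc1cc([C@](O)(CCN(C)C)[C@@H](c2cc3cc(C#N)ccc3nc2OC)c2cccc(C)c2F)cc(OC(F)F)n1` gives 8600 ng.h/mL

In this assay, for the measured compounds named here, compound 2, at 8600 ng.h/mL, lies within the scatter of compound 1, the only other measured member of the series. Compound 3 `COc1cc([C@](O)(CCN(C)C)[C@@H](c2cc3cc(C#N)ccc3nc2OC)c2ccnc(OC)c2OC)cc(OC(F)F)n1` has not yet been measured. It differs from compound 2 by 2,3-dimethoxypyridin-4-yl in place of 2-fluoro-3-methylphenyl on a saturated chain carbon bound to an aromatic carbon and a saturated chain carbon, with 2,3-dimethoxypyridin-4-yl in place of 2-fluoro-3-methylphenyl on a saturated chain carbon bound to an aromatic carbon and a saturated chain carbon.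

Going by the values given here, no measured pair of compounds differing in one place shows the size of this change. Compound 1, which also carries 2,3-dimethoxypyridin-4-yl, gives 12700 ng.h/mL, so no step beyond the scatter is expected in this assay. The estimated step of a 1.2-fold higher number from compound 2 to compound 3 (0.07 log units; within the scatter) is therefore small and has no firm direction. For compound 3 the estimate is 10000 ng.h/mL, with an expected range from 4500 ng.h/mL to 22000 ng.h/mL.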

Compound 3, area under the concentration-time curve: 3000 ng.h/mL
Compound 3: the middle estimate sits 3.3-fold (0.52 log units) above what was measured; measured number below the stated range.
By their numbers in this assay, from the lowest: compound 3; then compounds 2 and 1 (each within the scatter of the next).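

In this assay, the saturated chain carbon bound to an aromatic carbon and a saturated chain carbon proves sensitive to the ring it carries: 2,3-dimethoxypyridin-4-yl in place of 2-fluoro-3-methylphenyl gives a 2.9-fold lower number from compound 2 to compound 3 (0.46 log units; beyond the scatter). For the compounds shown here, this is the only single-place step available, and it lies beyond the scatter. Compound 1 also carries 2,3-dimethoxypyridin-4-yl but differs from compound 3 in other places, and no measurement on these compounds accounts for the step.

From the compounds shown here alone, the pair changes the ring nitrogen and both methoxy groups together, so the part of the new group that goes with the lower number stays open; an unsubstituted pyridin-4-yl at this place would separate them. Going by these compounds, whether the step holds on a core carrying bromine instead of the nitrile also remains open.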